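The source may hold more compounds than are shown below. What is called first, only, known or untested is meant among the compounds shown, and "the series" means these compounds.

Measured compounds:
- compound 1, `COCC[C@@H]1C[C@@H](c2ccc(Cl)c(Cl)c2)[C@H](NC(=O)c2cc(-c3c(Cl)cnn3C)c(Cl)o2)CN1`, 1060 nM in a functional assay on OVCAR-8 cells (Homo sapiens) for antiproliferative activity; on this read-out higher numbers stand for weaker inhibition and lower numbers for stronger inhibition
- compound 2, `Cn1ncc(Cl)c1-c1cc(C(=O)N[C@@H]2CN[C@H](CC(=O)NC3CCC3)C[C@H]2c2ccc(Cl)c(Cl)c2)oc1Cl`, 610 nM
- compound 3, `CNC(=O)C[C@@H]1C[C@@H](c2ccc(Cl)c(Cl)c2)[C@H](NC(=O)c2cc(-c3c(Cl)cnn3C)c(Cl)o2)CN1`, 1130 nM

Compound 3 stands among these three with its number separated from neither neighbour beyond the scatter: the step of a 1.1-fold higher number from compound 1 to compound 3 (0.03 log units; within the scatter) and the step of a 1.9-fold higher number from compound 2 to compound 3 (0.27 log units; within the scatter) both stay inside the usual spread, so the three compounds cannot be told apart on this read-out.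

Compound 4, `CCC[C@@H]1C[C@@H](c2ccc(Cl)c(Cl)c2)[C@H](NC(=O)c2cc(-c3c(Cl)cnn3C)c(Cl)o2)CN1`, differs from compound 3 at the same chain carbon that carries the variation across compounds 1, 2 and 3: ethyl in place of methylcarbamoyl on a saturated chain carbon bound to a saturated ring carbon. The measured steps that bear on this position are a 1.7-fold lower number from compound 1 to compound 2 (0.24 log units; within the scatter) and a 1.1-fold higher number from compound 1 to compound 3 (0.03 log units; within the scatter), and each was within the scatter, although neither removes the donor and acceptor as this change does. On that basis no step beyond the scatter is expected for compound 4, and its number in this assay is expected to lie near compound 3, the step of a 1.1-fold lower number from compound 3 to compound 4 (0.05 log units; within the scatter) being the estimated outcome. Compound 4 is estimated at 1000 nM, within 400 nM to 2500 nM.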

Compound 4, half-maximal inhibitory concentration: 1620 nM
Estimate against measurement, compound 4: 1.6-fold (0.21 log units) below; low and high end bracket the measured number.
By their numbers in this assay, from the lowest: compounds 2, 1, 3 and 4 (each within the scatter of the next, the first and the last beyond it).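

In this assay, ethyl can stand on this chain carbon in place of methylcarbamoyl, losing the amide hydrogen and carbonyl, with no separation beyond the scatter (a 1.4-fold higher number from compound 3 to compound 4 (0.16 log units; within the scatter)), and the same holds against the methoxymethyl chain (a 1.5-fold higher number from compound 1 to compound 4 (0.18 log units; within the scatter)). Among the compounds shown here, the position does show a modest difference for the first time when ethyl replaces cyclobutylcarbamoyl (a 2.7-fold higher number from compound 2 to compound 4 (0.42 log units; beyond the scatter)), although compound 3, which also carries an amide, stays within the scatter of both compound 2 and compound 4. No available evidence accounts for this difference.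

Open, as far as these compounds go, is whether an amine or a carboxylic acid on this chain carbon would separate from compound 3 beyond the scatter. A chain longer than propyl would show whether the number in this assay keeps the same level without the amide.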